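The source may hold more compounds than are shown below. What is called first, only, known or untested is meant among the compounds shown, and "the series" means these compounds.

Measured compounds in the series:

- compound 1, `COc1cccc(C(=O)Oc2cc3c(cc2C)[C@@H](C(C)C)CC=C3C)c1`: 24.2%
- compound 2, `CC1=CC[C@H](C(C)C)c2cc(C)c(OC(=O)c3cccc(C)c3)cc21`: "not active" (no number reported)

In a functional assay on SK-LU-1 cells (Homo sapiens) for antiproliferative activity, read by sulforhodamine B assay, with a stated time of 48 h, tested at 50 uM (a lower number here means less inhibition, a higher number more inhibition at the concentration tested (going by the name of the read-out)), compound 1 gives 24.2%. In this assay compound 2 is reported as "not active" (no number reported), with no number attached, so compound 2 stands with no single figure to compare against compound 1; all that the two values show is that compound 1 reaches a modest inhibition while compound 2 was not reported with one.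

Compound 3, `COc1ccc(C(=O)Oc2cc3c(cc2C)[C@@H](C(C)C)CC=C3C)cc1`, has not been measured. It differs from compound 2 in one place: 4-methoxyphenyl in place of 3-methylphenyl on a carbonyl carbon. For the measured compounds named here, no measured step between two compounds that differ in one place exists in this set, so the size of the change from compound 2 to compound 3 cannot be read from a counted step. Compound 1 carries a methoxy substituent on the same ring and gives 24.2%, which suggests that a methoxy-bearing ester can sit at a low but reported inhibition. A small rise relative to compound 2, of a size that need not exceed the usual scatter, is expected for compound 3.

In this assay compound 3 is expected to give 18%, within an estimated range of 0% to 38%.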

Compound 3, a percentage reported as inhibition, at one concentration (the size of the read-out at that concentration, not a potency): 18.6%
Beside the measured number, compound 3's estimate is 0.6 percentage points below it, within the range that was stated.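

In this assay, moving from 3-methoxyphenyl to 4-methoxyphenyl on a carbonyl carbon gives a number 5.6 percentage points lower from compound 1 to compound 3 (within the scatter), so the two methoxy-bearing aryl groups cannot be told apart at this position. For the compounds shown here, compound 2, with 3-methylphenyl, is reported as "not active" (no number reported), while compound 3 gives 18.6%; the step between them cannot be read as a size, and the printed values show only that compound 3 has a figure and compound 2 has none. No independent measurement bears on the reason for these values.

On these data alone, whether an amine or a carboxylic acid on the same aryl ring, or a longer alkyl chain in place of that ring on the carbonyl carbon, would carry inhibition in this assay clearly past the level of compound 1 and compound 3 remains open. Also open is how the compounds shown would rank as potencies, since each figure here is a single-concentration read-out and gives no concentration-response information.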